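The source may report more compounds than this note shows. Statements on the series, on what has been measured and on what is new or still open speak of the compounds shown alone.

Measured in a functional assay on C6 cells (Rattus norvegicus) for inhibition, read by sulforhodamine B assay, with a stated time of 72 h; on this read-out lower numbers stand for an effect already at smaller amounts and higher numbers for an effect only at larger amounts of compound:
- compound 1 `O=C(/C=C/c1ccc([N+](=O)[O-])o1)c1ccc(I)cc1`: 2100 nM
- compound 2 `O=C(/C=C/c1ccc([N+](=O)[O-])o1)c1ccc(N2CCCCC2)cc1`: 48700 nM

Among the measured compounds shown here, of these two, compound 2 stands highest, with compound 1 as its only neighbour. Compound 3 `O=C(/C=C/c1ccc(Cl)s1)c1ccc(N2CCCCC2)cc1` has 5-chlorothiophen-2-yl in place of 5-nitrofuran-2-yl on a double-bonded chain carbon bound to a double-bonded chain carbon. For the measured compounds named here, the only measured step, a 23-fold higher number from compound 1 to compound 2 (1.37 log units; beyond the scatter), is large, but it is piperidin-1-yl in place of iodo on an aromatic carbon, a change at a different place. Going by the values given here, no measured step covers the present exchange, so the data give no direction for it. Among the compounds with values here, they show only that one change in these compounds moved the number far, so the range is kept wide. The expected result is a 1.4-fold lower number from compound 2 to compound 3 (0.14 log units; within the scatter), with no step beyond the scatter anticipated. The estimate for compound 3 is 35000 nM, with an expected range from 9000 nM to 130000 nM.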

Compound 3, half-maximal effective concentration: 36600 nM
The estimate for compound 3 lay 1.0-fold (0.02 log units) below the measured number, and the stated range covers the measured number.
By their numbers in this assay, from the lowest: compound 1; then compounds 3 and 2 (each within the scatter of the next).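

In this assay, 5-chlorothiophen-2-yl in place of 5-nitrofuran-2-yl on a double-bonded chain carbon bound to a double-bonded chain carbon gives a 1.3-fold lower number from compound 2 to compound 3 (0.12 log units; within the scatter) and so does not separate the two compounds. The earlier pair showed a large step only at the aromatic carbon; this position now has a reading of its own, and with piperidin-1-yl held constant, 5-nitrofuran-2-yl is not needed for a number of this size. Nothing available bears on why the two groups read alike.

Open, on these data alone, is whether the same exchange stays within the scatter with iodo on the aromatic carbon, as in compound 1 at 2100 nM in this series. Also open, as far as these compounds go, is how a primary amine or a carboxylic acid would read at that aromatic carbon.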